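Swapping Fluoro for Ethyl on a Weak TLR4 Antagonist

The source may report more compounds than this note shows. Statements on the series, on what has been measured and on what is new or still open speak of the compounds shown alone.

Measured compounds:
- compound 1, `CCOc1ccc(OCC(O)CNCCOc2ccccc2OC)cc1`: "not active" (no number reported)
- compound 2, `CCOc1ccc(OCCC(O)CNCCOc2ccccc2OC)cc1`: "not active" (no number reported)
- compound 3, `Cc1nn(Cc2ccccc2Cl)c(C)c1CN(C)CC(O)CCOc1ccc(F)cc1`: 55400 nM

The read-out is an assay on cells for antagonist activity at Toll-like receptor 4 (Homo sapiens), with a stated time of 24 h; on this read-out higher numbers stand for weaker inhibition and lower numbers for stronger inhibition. Compound 1 gives "not active" (no number reported) in this assay, with no number reported. Compound 2 likewise gives "not active" (no number reported) in this assay, again without a number. Compound 3 is therefore the only entry with a measured value, and that value, 55400 nM, marks it as a weak inhibitor. For the measured compounds named here, no step between two measured compounds is available, so nothing is known yet about how any single change moves the number.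

Compound 4, `CCc1ccc(OCCC(O)CN(C)Cc2c(C)nn(Cc3ccccc3Cl)c2C)cc1`, differs from compound 3 in one place: ethyl in place of fluoro on an aromatic carbon. Going by the values given here, no measured pair shows what such a swap does, and the other two compounds, which carry a different core, give no number at all.

The estimate for compound 4 is 50000 nM in this assay, with an expected range from 15000 nM to 200000 nM. That is, the step of a 1.1-fold lower number from compound 3 to compound 4 (0.04 log units; within the scatter) is expected to stay within the usual scatter, in no clear direction, with a real chance that this assay again reports no number.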

Compound 4, half-maximal inhibitory concentration: 26000 nM
Compound 4: middle estimate off by 1.9-fold (0.28 log units), on the high side, and the stated range covers the measured number.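

In this assay, for the compounds shown here, the swap of 4-fluorophenoxy for 4-ethylphenoxy gives a 2.1-fold lower number from compound 3 to compound 4 (0.33 log units; beyond the scatter), the first measured step, and it lies beyond the usual scatter, though the change is modest. It shows that this place on the aromatic ring, para to a large group, can carry ethyl, with two heavy atoms, in place of fluoro, with one, without losing the measured activity, and that the number even moves a little in the favourable direction, while both compounds remain weak inhibitors. Nothing in the available data explains why the number moves.

Going by these compounds, a single pair cannot show whether the trend continues at this place, so it remains open what a propyl chain, a methoxy group, an amine or a carboxylic acid would do there. On these data alone, it also remains open whether the same swap would have any effect on the different core of compound 1 and compound 2, since neither gives a number that could serve as a starting point.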